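Two thiosemicarbazone-related compounds and glioma cell growth

A few compounds are considered here, and "the series" means these few. Any claim that something is new, unique, unknown or untested is made for them only; others in the source may bear on it.

Compound 1 `CC1=CC[C@H](C(C)(C)N=C=S)CC1` gives 29100 nM in a functional assay on U-251 cells (Homo sapiens) for inhibition, read by sulforhodamine B assay, with a stated time of 48 h; on this read-out higher numbers stand for weaker inhibition of growth and lower numbers for stronger inhibition of growth.
Compound 2 `CC1=CC[C@H](C(C)(C)NC(=S)N/N=C/c2ccccc2O)CC1` gives 6400 nM in this assay.

Of the two numbers measured, compound 2 holds the lower one; compound 1 stands higher by a gap beyond the usual scatter, so compound 2 is the stronger of the pair. Compound 3 `CC1=CC[C@H](C(C)(C)NC(=S)N/N=C/c2ccc(Cl)cc2)CC1` differs from compound 2 by 4-chlorophenyl in place of 2-hydroxyphenyl on a carbon with a double bond to nitrogen. Within the data shown here, no measured pair isolates this change, so there is no step to lean on. The expected step of a 1.3-fold higher number from compound 2 to compound 3 (0.10 log units; within the scatter) is small, not beyond the scatter in either direction. Compound 3 is expected to give 8000 nM, with a range from 2000 nM to 30000 nM.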

Compound 3, concentration for 50% growth inhibition: 69500 nM
Beside the measured number, compound 3's estimate is 8.7-fold (0.94 log units) below it, and the stated range ends below it.
By their numbers in this assay, from the lowest: compound 2; then compound 1; then compound 3.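

In this assay, the group on the carbon with a double bond to nitrogen proves to matter: 4-chlorophenyl in place of 2-hydroxyphenyl gives an 11-fold higher number from compound 2 to compound 3 (1.04 log units; beyond the scatter). The earlier compounds shown here could not show that this position responds so strongly to such an exchange. No available evidence bears on the size of this step.

Two things change at once, the substituent and its place on the ring, so the compounds shown leave open which one carries the step. Plain phenyl, 4-hydroxyphenyl and 2-chlorophenyl remain open at this position.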